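Fluoroanilino in place of cyclohexyloxy on the shared core

The compounds below may be only part of what the source reports. "The series", "measured", "known", "first", "only" and "open" are said of these compounds alone.

Compound 2 `O=C(C1=C(OC2CCCCC2)C(=O)N(CCCn2ccnc2)C1c1ccc(Br)cc1)c1ccccc1` gives 22400 nM in a functional assay on U2OS cells (Homo sapiens) for antiproliferative activity, read by MTT assay, with a stated time of 72 h (on this read-out lower numbers stand for stronger inhibition and higher numbers for weaker inhibition), the lowest of the two numbers recorded; compound 3 `O=C(C1=C(Nc2ccccc2)C(=O)N(CCCn2ccnc2)C1c1ccc(Br)cc1)c1ccccc1` gives 25700 nM, and compound 1 `O=C(C1=C(O)C(=O)N(CCCn2ccnc2)C1c1ccc(Br)cc1)c1ccccc1` gives "not active" (no number reported), with no number reported. Compound 4 `O=C(C1=C(Nc2ccc(F)cc2)C(=O)N(CCCn2ccnc2)C1c1ccc(Br)cc1)c1ccccc1` differs from compound 2 by (4-fluorophenyl)amino in place of cyclohexyloxy on a double-bonded ring carbon. Among the compounds with values here, the only step that bears on it is the same kind of exchange from compound 2 to compound 3, where a 1.1-fold higher number from compound 2 to compound 3 (0.06 log units; within the scatter). Within the data shown here, because that step a 1.1-fold higher number from compound 2 to compound 3 (0.06 log units; within the scatter) stayed within the scatter, no movement beyond the scatter is expected in this assay for compound 4, and a fluorine on the anilino ring has no measured precedent here. The estimated step from compound 2 to compound 4 is a 1.1-fold higher number from compound 2 to compound 4 (0.05 log units; within the scatter). Compound 4 is expected to give 25000 nM, within 10000 nM to 60000 nM.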

Compound 4, half-maximal inhibitory concentration: 30000 nM
For compound 4 the middle estimate is 1.2-fold (0.08 log units) below the measured one, within the range that was stated.
By their numbers in this assay, from the lowest: compounds 2, 3 and 4 (each within the scatter of the next).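

In this assay, (4-fluorophenyl)amino in place of cyclohexyloxy on the double-bonded ring carbon gives a 1.3-fold higher number from compound 2 to compound 4 (0.13 log units; within the scatter) and adds a second anilino-type group to the same narrow band of numbers. Fluoro in place of hydrogen on an aromatic carbon gives a 1.2-fold higher number from compound 3 to compound 4 (0.07 log units; within the scatter) and is the first reading of a substituent on the anilino ring. No measurement at hand accounts for these results.

As far as these compounds go, it remains open whether a morpholino group or a longer alkoxy chain on this carbon would move the number beyond the scatter. Also open, from the compounds shown here alone, is whether a carboxylic acid or methoxy group on the anilino ring would do so.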